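A few compounds are considered here, and "the series" means these few. Any claim that something is new, unique, unknown or untested is made for them only; others in the source may bear on it.

Compound 1 `CNC(=O)[C@@]12C[C@@H]1[C@@H](n1cnc3c(NC)nc(C#Cc4ccc(-c5ccccc5)cc4)nc31)[C@H](O)[C@@H]2O`: 18%
Compound 2 `CNC(=O)[C@@]12C[C@@H]1[C@@H](n1cnc3c(NC)nc(C#Cc4ccc(Cl)cc4)nc31)[C@H](O)[C@@H]2O`: 13%
Compound 3 `CNC(=O)[C@@]12C[C@@H]1[C@@H](n1cnc3c(NC)nc(C#Cc4ccc(CO)cc4)nc31)[C@H](O)[C@@H]2O`: 16%

In an assay on CHO cells for displacement of a labelled ligand from adenosine receptor A1 (Homo sapiens), read by scintillation counting, with a stated time of 60 min, tested at 10 uM (on this read-out lower numbers stand for less inhibition and higher numbers for more inhibition at the one concentration tested (going by the name of the read-out)), compound 3 gives 16%, the second highest of the three numbers, with compound 1 nearest and compound 2 furthest. Compound 4 `CNC(=O)[C@@]12C[C@@H]1[C@@H](n1cnc3c(NC)nc(C#Cc4ncccn4)nc31)[C@H](O)[C@@H]2O` differs from compound 3 in one place: pyrimidin-2-yl in place of 4-(hydroxymethyl)phenyl on a triple-bonded carbon. The measured steps, a number 5 percentage points lower from compound 1 to compound 2 (within the scatter), a number 2 percentage points lower from compound 1 to compound 3 (within the scatter) and a number 3 percentage points higher from compound 2 to compound 3 (within the scatter), all exchange the group on an aromatic carbon while the ring itself stays, and each lies within the scatter. No measured step replaces the ring as in compound 4, so the data give no direct guide; on what is shown, a step beyond the scatter is not expected. Compound 4 is therefore estimated at 14%, within 3% to 27%, a step of a number 2 percentage points lower from compound 3 to compound 4 (within the scatter) expected to stay within the scatter.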

Compound 4, a percentage reported as inhibition, at one concentration (the size of the read-out at that concentration, not a potency): 25%
For compound 4 the middle estimate is 11 percentage points below the measured one; low and high end bracket the measured number.
By their numbers in this assay, from the lowest: compounds 2, 3, 1 and 4 (each within the scatter of the next, the first and the last beyond it).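

Exchanging the whole ring on the triple-bonded carbon, and not only the group it carries, gives in this assay the first step beyond the scatter among these compounds, a number 12 percentage points higher from compound 2 to compound 4 (beyond the scatter). Within the data shown here, the same kind of exchange stays within the scatter against the other two compounds, at a number 9 percentage points higher from compound 3 to compound 4 (within the scatter) and a number 7 percentage points higher from compound 1 to compound 4 (within the scatter), so the gain holds against only one comparison. Nothing given here accounts for this result. From the compounds shown here alone, it remains open how a pyridin-2-yl group would compare with pyrimidin-2-yl on the triple-bonded carbon. Also open, going by these compounds, is what an amine or a methoxy group on the pyrimidine ring would do.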